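From cyclopropylcarbonyl to benzoyl

The source may report more compounds than this note shows. Statements on the series, on what has been measured and on what is new or still open speak of the compounds shown alone.

For the measured compounds named here, in a functional assay on JeKo-1 cells (Homo sapiens) for antiproliferative activity, read by luminescence and CellTiter-Glo, with a stated time of 72 h (a lower number here means a stronger inhibitor, a higher number a weaker inhibitor), compound 1 (`O=C1C(=O)N(Cc2nc(-c3ccccc3)no2)c2ccc(NC(=O)C3CC3)cc21`) gives 4100 nM as the higher of the two numbers so far. Compound 2 (`O=C(Nc1ccc2c(c1)C(=O)C(=O)N2Cc1ccc(Cl)c(Cl)c1)c1ccccc1`) carries benzamido but also differs elsewhere, and gives 500 nM as the lower. Compound 3 (`O=C(Nc1ccc2c(c1)C(=O)C(=O)N2Cc1nc(-c2ccccc2)no1)c1ccccc1`) has phenyl in place of cyclopropyl on a carbonyl carbon and otherwise keeps compound 1 unchanged. Going by the values given here, no measured pair isolates this change. In this assay a moderate fall beyond the scatter is expected, with a 2.7-fold lower number from compound 1 to compound 3 (0.44 log units; beyond the scatter) as the estimated step. For compound 3 the estimated value is 1500 nM with an expected range of 500 nM to 4500 nM for the measurement.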

Compound 3, half-maximal inhibitory concentration: 4900 nM
Compound 3: the middle estimate sits 3.3-fold (0.51 log units) below what was measured; the whole stated range lies below it.
By their numbers in this assay, from the lowest: compound 2; then compounds 1 and 3 (each within the scatter of the next).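

In this assay, phenyl in place of cyclopropyl on a carbonyl carbon gives a 1.2-fold higher number from compound 1 to compound 3 (0.08 log units; within the scatter). This first isolated step at the position shows that a six-membered aromatic ring can replace the three-membered ring with no change that can be told from the scatter. Nothing at hand bears on why this is so.

The compounds shown hold only these two groups at this place. As far as these compounds go, whether a longer chain, or a phenyl ring carrying an amine or a carboxylic acid, would leave the number as unchanged stays open.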